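A few compounds are considered here, and "the series" means these few. Any claim that something is new, unique, unknown or untested is made for them only; others in the source may bear on it.

Working notes on the series in a functional assay on NCI-H460 cells (Homo sapiens) for inhibition, with a stated time of 72 h; on this read-out lower numbers stand for stronger inhibition and higher numbers for weaker inhibition. Compound 1 `COc1ccc(S(=O)(=O)N2CCc3cccc(-c4ccc(N(C)C)cc4)c32)cc1` gives 556 nM, compound 2 `COc1ccc(S(=O)(=O)N2CCc3cccc(-c4ccc(F)cc4)c32)cc1` gives 95.5 nM and compound 3 `COc1ccc(S(=O)(=O)n2ccc3cccc(-c4ccc(C#N)cc4)c32)cc1` gives 172 nM. Compound 2 stands level with compound 3 within the scatter and clear of compound 1.

Compound 4 `COc1ccc(S(=O)(=O)N2CCc3cccc(-c4cccnc4)c32)cc1` carries pyridin-3-yl in place of 4-fluorophenyl on an aromatic carbon of the shared core: pyridin-3-yl in place of 4-fluorophenyl on an aromatic carbon. Among the compounds with values here, the only measured step bearing on this change is a 5.8-fold lower number from compound 1 to compound 2 (0.77 log units; beyond the scatter), a modest step with fluoro in place of dimethylamino on an aromatic carbon. Within the data shown here, it shows that the number in this assay moves with a substituent on this aryl group, but no measured step exchanges the ring itself, so the support is indirect. With compound 2 at the low end of the measured values, a modest rise is expected, smaller than that measured step. The expected change is a 2.3-fold higher number from compound 2 to compound 4 (0.36 log units; beyond the scatter). For compound 4 the estimated value is 220 nM, with an expected range of 70 nM to 700 nM.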

Compound 4, half-maximal inhibitory concentration: 89.6 nM
Compound 4: middle estimate off by 2.5-fold (0.39 log units), on the high side; measured number inside the range.
By their numbers in this assay, from the lowest: compounds 4, 2 and 3 (each within the scatter of the next); then compound 1.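

In this assay the aryl ring itself, and not only a substituent on it, can now be exchanged on the shared core: a 1.1-fold lower number from compound 2 to compound 4 (0.03 log units; within the scatter) lies within the scatter, so 4-fluorophenyl and pyridin-3-yl are not told apart here. The other new step, a 6.2-fold lower number from compound 1 to compound 4 (0.79 log units; beyond the scatter), lies beyond the scatter and leaves 4-(dimethylamino)phenyl as the group that stands apart among the three aryl groups on this core, now against two different partners. Nothing measured here bears on the reason for either step.

Whether the place of the ring nitrogen matters stays open, with pyridin-2-yl, pyridin-4-yl and a saturated ring such as piperidin-4-yl outside the compounds shown. The 4-cyanophenyl group appears only on the different core of compound 3, so its contribution cannot be separated from that of the core.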